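Compound 3 to compound 4: an aryl change on sulfur

The source may hold more compounds than are shown below. What is called first, only, known or untested is meant among the compounds shown, and "the series" means these compounds.

Of the compounds shown here, three sharing one core have been measured in a functional assay on HCT-116 cells (Homo sapiens) for inhibition, read by CCK-8 assay, with a stated time of 72 h, tested at 8 uM (a lower number here means less inhibition of growth, a higher number more inhibition of growth at the concentration tested), so far. Compound 1 `COc1ccc(SCc2ccc(C(=O)Nc3ccccc3N)cc2)cc1` gives 90.1% in this read-out, compound 2 `CCc1ccc(SCc2ccc(C(=O)Nc3ccccc3N)cc2)cc1` gives 79.1% and compound 3 `Nc1ccccc1NC(=O)c1ccc(CSc2cccc(F)c2)cc1` gives 81.4% under the same conditions. Compound 3 cannot be separated from either of the others, with a number 8.7 percentage points lower from compound 1 to compound 3 (within the scatter) and a number 2.3 percentage points higher from compound 2 to compound 3 (within the scatter) as the two steps that reach it. For the measured compounds named here, the only separated pair shows a number 11 percentage points lower from compound 1 to compound 2 (beyond the scatter) for ethyl in place of methoxy on an aromatic carbon.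

The next structure is compound 4 `Cc1ccc(SCc2ccc(C(=O)Nc3ccccc3N)cc2)cc1`, with 4-methylphenyl in place of 3-fluorophenyl on a sulfur as its difference from compound 3. The nearest evidence is the exchange at the same sulfur, a number 2.3 percentage points higher from compound 2 to compound 3 (within the scatter), which stayed small. The other exchange there, a number 8.7 percentage points lower from compound 1 to compound 3 (within the scatter), also stayed small. Going by the values given here, the 4-methylphenyl group has no measured example yet, though the 4-ethylphenyl of compound 2 at 79.1% and the 4-methoxyphenyl of compound 1 at 90.1% give an expected bracket. The expected outcome in this assay is a number 2.6 percentage points higher from compound 3 to compound 4 (within the scatter) and thus no step beyond the scatter. Compound 4 is estimated at 84% with an expected range of 73% to 93% as the working figure.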

Compound 4, percent growth inhibition at one concentration: 84%
Compound 4: middle estimate and measured number agree at the digits printed; the range from low to high includes it.
By their numbers in this assay, from the lowest: compounds 2, 3, 4 and 1 (each within the scatter of the next, the first and the last beyond it).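

The exchange of 3-fluorophenyl for 4-methylphenyl on the sulfur stays small in this assay (a number 2.6 percentage points higher from compound 3 to compound 4 (within the scatter)), so this position accepts a methyl-bearing ring as well as a fluorine-bearing one without a separable change. Methyl in place of the ethyl of compound 2 (a number 4.9 percentage points higher from compound 2 to compound 4 (within the scatter)) and methyl in place of the methoxy of compound 1 (a number 6.1 percentage points lower from compound 1 to compound 4 (within the scatter)) are both small as well, so the one separated pair in the series (a number 11 percentage points lower from compound 1 to compound 2 (beyond the scatter)) now has a compound that cannot be told apart from either end, and that gap can no longer be read as a clean break between the methoxy and alkyl groups. No accompanying measurement offers an explanation for these numbers.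

From the compounds shown here alone, whether an amine, a carboxylic acid or a longer chain such as butyl on the same aromatic ring would give a step beyond the scatter remains open. Also open, going by these compounds, is whether compounds that cannot be separated at this single concentration would stay inseparable across a full concentration range.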